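The source may report more compounds than this note shows. Statements on the series, on what has been measured and on what is new or still open speak of the compounds shown alone.

Of the compounds shown here, two have been tested in a functional assay on DU-145 cells (Homo sapiens) for inhibition, read by sulforhodamine B assay, with a stated time of 48 h, tested at 10 uM; a higher number here means more inhibition at the concentration tested (going by the name of the read-out), a lower number less inhibition. Compound 1 `CCc1ccc(-c2cn3ccnc3c(-c3ccc4ncn(Cc5ccccc5)c4c3)n2)cc1` gives 19.1%, while compound 2 `c1cn2cc(-c3ccc4c(c3)ncn4C3CCCCC3)nc(-c3ccc4ncn(C5CCCCC5)c4c3)c2n1` gives 8.72%, the lower of the two numbers and beyond the scatter from compound 1. Compound 3 `c1ccc(Cn2cnc3ccc(-c4nc(-c5ccc6c(c5)ncn6C5CCCCC5)cn5ccnc45)cc32)cc1` has not been measured; it differs from compound 2 by benzyl in place of cyclohexyl on an aromatic nitrogen. Within the data shown here, no step between measured compounds isolates this change, so the expectation rests only on compound 1 carrying a benzyl and sitting higher than compound 2. A modest rise is therefore expected, a number 5.3 percentage points higher from compound 2 to compound 3 (within the scatter), within or near the scatter. For compound 3 the estimated inhibition is 14%, with a range of 4% to 25%.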

Compound 3, a percentage reported as inhibition, at one concentration (the size of the read-out at that concentration, not a potency): -28.2%
Beside the measured number, compound 3's estimate is 42.2 percentage points above it, and the stated range ends above it.
By their numbers in this assay, from the lowest: compound 3; then compound 2; then compound 1.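

In this assay, among these compounds, a number 36.9 percentage points lower from compound 2 to compound 3 (beyond the scatter) is the first reading of a single change: benzyl in place of cyclohexyl on an aromatic nitrogen. This position is therefore not indifferent to its substituent, and with the rest of the molecule held constant, benzyl goes with the lower number, with compound 3 falling to a negative value.

Open is how a methyl group, or a longer chain ending in an amine, would read at this nitrogen, and no measurement shown accounts for the drop.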